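Adding a Third Methoxy Group to a Lactam Analogue

The source may report more compounds than this note shows. Statements on the series, on what has been measured and on what is new or still open speak of the compounds shown alone.

Of the compounds shown here, three have been measured in a functional assay on U-251 cells (Homo sapiens) for inhibition, read by sulforhodamine B assay, with a stated time of 48 h (a lower number here means a stronger inhibitor of growth, a higher number a weaker inhibitor of growth), so far. Compound 1 `COc1cc(/C=C/C2CC=CC(=O)O2)cc(OC)c1OC` gives 25.1 uM, the lower of the two plain numbers. Compound 3 `COc1cc(/C=C/C2CC=CC(=O)N2)cc(OC)c1` gives 170 uM, the higher of the two plain numbers, and the gap between compound 1 and compound 3 lies beyond the usual scatter. Compound 2 `COc1ccc(/C=C/C2CC=CC(=O)N2)cc1OC` reaches only a limit of the assay rather than a number, namely > 964 uM; the limit of > 964 uM in this assay, at which 1 of the 3 values shown sits, records that one of the three values sits at this limit.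

Compound 4 `COc1cc(/C=C/C2CC=CC(=O)N2)cc(OC)c1OC` has not yet been measured. It differs from compound 3 by one change: methoxy in place of hydrogen on an aromatic carbon. Compound 4 thereby carries the same three methoxy groups that compound 1 carries, while keeping the lactam of compound 3.

Because compound 1 gives 25.1 uM, a step in the lower direction is expected from compound 3 to compound 4, though smaller than the gap between compound 1 and compound 3; the expected step is a 1.9-fold lower number from compound 3 to compound 4 (0.28 log units; within the scatter). For compound 4 the estimate in this assay is 90 uM, with a range from 30 uM to 400 uM.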

Compound 4, concentration for growth inhibition (reported as GI): > 864 uM
Compound 4: no number, only a limit; the forecaster's own chance of this, stated with the estimate: 10%; at least 9.6-fold (0.98 log units) between middle value and limit.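

In this assay, compound 4 gives no number, only a limit: the limit of > 864 uM in this assay, at which 1 of the 4 values shown sits. On the lactam, methoxy in place of hydrogen at this carbon, ortho to two methoxy groups and para to a group of 9 heavy atoms, weakens growth inhibition, with an at least 5.0-fold higher number from compound 3 to compound 4 (0.70 log units; beyond the scatter). With the three methoxy groups held fixed, exchanging the oxygen-containing ring for the lactam gives an at least 34-fold higher number from compound 1 to compound 4 (1.53 log units; beyond the scatter), while the step between compound 2 and compound 4 cannot be read, as both values are limits.

On these data alone, how far the true value of compound 4 lies past its limit remains open. So does whether this loss belongs to methoxy specifically or would also appear with a hydroxyl group or a fluorine atom at the same carbon.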